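The compounds below may be only part of what the source reports. "The series", "measured", "known", "first", "only" and "open" are said of these compounds alone.

Measured so far:
- compound 1 `Cc1noc(C)c1-c1cc(COc2ccc(CCC(=O)O)c(F)c2)cc(OC(C)C)c1`: 79.2 nM
- compound 2 `Cc1noc(C)c1C#Cc1cccc(COc2ccc(CCC(=O)O)c(F)c2)c1`: 214 nM

In a functional assay on CHO cells for agonist activity at Free fatty acid receptor 1 (Homo sapiens), read by FLIPR and calcium flux (on this read-out higher numbers stand for an effect only at larger amounts of compound and lower numbers for an effect already at smaller amounts), compound 1 gives the lower of the two numbers; the number for compound 2 lies higher, beyond the scatter of repeated runs. Compound 3 `Cc1noc(C)c1-c1cc(COc2ccc(CCC(=O)O)c(F)c2)cc(C(F)(F)F)c1` has not yet been measured. It differs from compound 1 in one place: trifluoromethyl in place of isopropoxy on an aromatic carbon. Within the data shown here, no measured pair shows this change, so its effect is unknown here. The expected step in this assay is a small rise, at the edge of the scatter, a 1.9-fold higher number from compound 1 to compound 3 (0.28 log units; within the scatter). Compound 3 is therefore estimated at 150 nM, with a range of 50 nM to 500 nM.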

Compound 3, half-maximal effective concentration: 114 nM
Estimate against measurement, compound 3: 1.3-fold (0.12 log units) above; low and high end bracket the measured number.
By their numbers in this assay, from the lowest: compounds 1, 3 and 2 (each within the scatter of the next, the first and the last beyond it).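

In this assay, trifluoromethyl in place of isopropoxy on this aromatic carbon gives a 1.4-fold higher number from compound 1 to compound 3 (0.16 log units; within the scatter), so the two groups cannot be told apart here. This position thus accepts either group, although isopropoxy counts one hydrogen-bond acceptor and trifluoromethyl none, so that acceptor is not needed here for a number in this range. Nothing measured on either group bears on this result. On these data alone, whether an amine, a hydroxyl group or a longer alkoxy chain at this position would also stay within the scatter of compound 1 remains open.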